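A few compounds are considered here, and "the series" means these few. Any claim that something is new, unique, unknown or untested is made for them only; others in the source may bear on it.

Compound 1 `Cc1cccc(NC(=O)Nc2ccc(Oc3nc(C)cc(C)n3)cc2)c1` shows the shared core of this small set, and compound 2 `Cc1cc(C)nc(Oc2ccc(NC(=O)Nc3ccc(OC(F)(F)F)cc3)cc2)n1` and compound 3 `Cc1cc(C)nc(Sc2ccc(NC(=O)Nc3ccccc3)cc2)n1` are close relatives of it. In a functional assay on MCF7 cells (Homo sapiens) for cytotoxicity, read by MTT assay, with a stated time of 3 days (on this read-out higher numbers stand for weaker inhibition and lower numbers for stronger inhibition), compound 1 gives "not determined" (no result reported). In this assay compound 2 returns only > 50000 nM, which is a limit of the assay rather than a number. Compound 3 likewise gives only a limit in this assay, > 50000 nM. Within the data shown here, compound 3 thus stands at the ceiling of the series, since (the limit of > 50000 nM in this assay, at which 2 of the 3 values shown sit); nothing in the data sets it apart from compound 2, and no step between two measured compounds is available at all.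

Compound 4 `Cc1cc(C)nc(Sc2ccc(NC(=O)Nc3ccc(Cl)cc3)cc2)n1` differs from compound 3 by chloro in place of hydrogen on an aromatic carbon. Among the measured compounds shown here, with no measured step to lean on, the size of this change in this assay cannot be read from the data, and the most that can be said is that compound 3 already sits at the limit. Compound 4 is therefore expected to remain at or close to that limit, with an estimated 50000 nM (range 20000 nM to 120000 nM). The expected step of a number no higher from compound 3 to compound 4 (the limit leaves the size open) is accordingly none beyond the scatter.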

Compound 4, half-maximal inhibitory concentration: 35300 nM
Compound 4: the middle estimate sits 1.4-fold (0.15 log units) above what was measured, within the range that was stated.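

Among these compounds, compound 4 is the first compound in this set to give a number rather than a limit of the assay, while the ceiling still applies elsewhere: the limit of > 50000 nM in this assay, at which 2 of the 4 values shown sit. Replacing hydrogen with chloro on an aromatic carbon, para to a large group, gives an at least 1.4-fold lower number from compound 3 to compound 4 (0.15 log units; that floor lies within the scatter). On these data alone, since compound 3 has only a limit, this step is a floor: it shows that this position can carry chloro and still give a reading in this assay, but it does not establish a change beyond the scatter, and the true size of the step stays unknown.

The other steps among these compounds cannot be read, so this one change stands alone, and the data offer no cause for it. What the compounds shown leave open is whether a fluoro, a methoxy, an amine or a carboxylic acid in the same place would give a number well clear of the limit, and whether chloro would behave the same way on the oxygen-linked compounds.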